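A few compounds are considered here, and "the series" means these few. Any claim that something is new, unique, unknown or untested is made for them only; others in the source may bear on it.

In an assay on a cell-free system (plasma) for inhibition of Dipeptidyl peptidase 4 (Rattus norvegicus), read by fluorescence (a lower number here means a stronger inhibitor, a higher number a weaker inhibitor), compound 1 `CN1CCN([C@@H]2CN[C@H](C(=O)N3CCSC3)C2)CC1` gives 81.1 nM, while compound 2 `O=C([C@@H]1C[C@H](N2CCN(c3ccccn3)CC2)CN1)N1CCSC1` gives 3.5 nM, the lowest of the two numbers. Within the data shown here, the only measured step is a 23-fold lower number from compound 1 to compound 2 (1.36 log units; beyond the scatter), a pyridin-2-yl in place of methyl on an amine nitrogen in a ring. Compound 3 `N#Cc1ccnc(N2CCN([C@@H]3CN[C@H](C(=O)N4CCSC4)C3)CC2)c1` differs from compound 2 by cyano in place of hydrogen on an aromatic carbon. No measured step touches that part of the shared core, so nothing shown speaks for a shift in either direction. Compound 3 is expected to give a step of no change at the digits printed from compound 2 to compound 3 (within the scatter) that stays within the scatter. The estimate for compound 3 is 3.5 nM, within 1.2 nM to 10 nM.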

Compound 3, half-maximal inhibitory concentration: 1.9 nM
Estimate against measurement, compound 3: 1.8-fold (0.27 log units) above, within the range that was stated.
By their numbers in this assay, from the lowest: compounds 3 and 2 (each within the scatter of the next); then compound 1.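

In this assay, placing a nitrile on the pyridin-2-yl group, opposite the ring nitrogen, gives a 1.8-fold lower number from compound 2 to compound 3 (0.27 log units; within the scatter), so this position accepts the group without a change that can be told from scatter. The larger step is still there with the nitrile present: a 43-fold lower number from compound 1 to compound 3 (1.63 log units; beyond the scatter). No measurement at hand explains either result. From the compounds shown here alone, whether an amine, a carboxylic acid or a methoxy group would be accepted at this same carbon stays open, as does how a nitrile would fare elsewhere on the ring.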